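The source may report more compounds than this note shows. Statements on the series, on what has been measured and on what is new or still open speak of the compounds shown alone.

Working notes on the series, in which two compounds built on a shared core have been measured so far. In an ADME assay on HeLa cells (Homo sapiens) for cytotoxicity, read by crystal violet staining, with a stated time of 72 h (a lower number here means that less compound is tolerated, a higher number that more compound is tolerated), compound 1 (`CCOC(=O)c1cc(CCCOc2ccc(-c3noc(C(F)(F)F)n3)cc2C(F)(F)F)on1`) gives 28400 nM as its reading, and compound 2 (`CN(C)C(=O)c1cc(CCCOc2ccc(-c3noc(C(F)(F)F)n3)cc2C(F)(F)F)on1`) gives 19200 nM as its reading. These two values lie within the scatter of each other, so compound 2 has no separate standing and sits level with compound 1 on the available numbers.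

The next compound is compound 3 (`CNC(=O)c1cc(CCCOc2ccc(-c3noc(C(F)(F)F)n3)cc2C(F)(F)F)on1`). Its difference from compound 2 is hydrogen in place of methyl on an amide-type nitrogen with hydrogen in place of methyl on an amide-type nitrogen, which takes dimethylcarbamoyl to methylcarbamoyl.

Within the data shown here, only one measured step bears on this change: a 1.5-fold lower number from compound 1 to compound 2 (0.17 log units; within the scatter) for dimethylamino in place of ethoxy on a carbonyl carbon. Among the measured compounds shown here, that step is within the scatter, and no measured compound yet carries the amide hydrogen, so the evidence is thin. No shift beyond the scatter is expected in this assay and no direction is favoured. The estimated change is a 1.1-fold higher number from compound 2 to compound 3 (0.06 log units; within the scatter) and would stay inside the scatter. For compound 3 the expected value is 22000 nM within an estimated range from 11000 nM to 45000 nM in this assay.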

Compound 3, half-maximal cytotoxic concentration: > 100000 nM
Compound 3 ended at the assay's limit; the forecaster's own chance of this, stated with the estimate: 10%; middle value at least 4.5-fold (0.65 log units) away from the limit.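

In this assay compound 3 reads > 100000 nM, which is a limit of the assay and not a number. On the amide-type nitrogen, hydrogen in place of methyl gives an at least 5.2-fold higher number from compound 2 to compound 3 (0.71 log units; beyond the scatter), and the change from the ester gives an at least 3.5-fold higher number from compound 1 to compound 3 (0.54 log units; beyond the scatter); both steps lie beyond the scatter, whereas a 1.5-fold lower number from compound 1 to compound 2 (0.17 log units; within the scatter) did not separate the ester from the dimethylamide, so this position responds to a change in this assay after all. Each new step is only a bound, and its full size stays unknown because of where the reading of compound 3 sits: the limit of > 100000 nM in this assay, at which 1 of the 3 values shown sits.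

As far as these compounds go, the finding rests on compound 3 alone, so it remains open whether it belongs to the amide hydrogen in general or to the methylcarbamoyl group in particular. An unsubstituted carboxamide, an ethylamide or a carboxylic acid in this place would help to decide that, and a compound reading inside the range of the assay would give the step a real size.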